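Quinoline ester to diethylamide: a step toward compound 3

This account rests on a few compounds, and the source may have more. Where it says the series, first, only, none or still open, it means among the compounds named here.

Measured so far:
Compound 1, `CCN(Cc1ccccc1)Cc1ccccc1C(=O)N(CC)CC`: 8210 nM
Compound 2, `CCOC(=O)c1c(CN(CC)Cc2ccccc2)nc2ccccc2c1-c1ccccc1`: 700 nM

Going by the values given here, in an assay on brain with Translocator protein (Rattus norvegicus) as the target (a higher number here means a weaker inhibitor, a lower number a stronger inhibitor), compound 2 gives the lower of the two numbers so far; the gap from compound 1 to compound 2 lies beyond the scatter, so compound 2 counts as the stronger inhibitor of the pair. Compound 3, `CCN(Cc1ccccc1)Cc1nc2ccccc2c(-c2ccccc2)c1C(=O)N(CC)CC`, keeps the core of compound 2 and changes one group: diethylamino in place of ethoxy on a carbonyl carbon. Among the compounds with values here, no step of this kind has been measured here, so its size is open. Compound 1 already carries a diethylcarbamoyl group on a simpler frame, and its value, 8210 nM, shows that the group alone does not secure potency. Still, on the core of compound 2 the author expects the amide to tighten binding, a step estimated as a 4.7-fold lower number from compound 2 to compound 3 (0.67 log units; beyond the scatter) in this assay. Compound 3 is therefore estimated at 150 nM, with a range from 30 nM to 700 nM.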

Compound 3, half-maximal inhibitory concentration: 373 nM
Compound 3: the middle estimate sits 2.5-fold (0.40 log units) below what was measured, within the range that was stated.
By their numbers in this assay, from the lowest: compounds 3 and 2 (each within the scatter of the next); then compound 1.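

Going by these compounds alone, this is the first step measured at this carbonyl carbon, and in this assay it reads a 1.9-fold lower number from compound 2 to compound 3 (0.27 log units; within the scatter) for diethylamino in place of ethoxy. The ethoxycarbonyl and diethylcarbamoyl compounds therefore cannot be told apart here, so on this core the larger group, with five heavy atoms against three and no counted hydrogen-bond acceptor of its own, leaves the reading within the scatter. No measurement shown here accounts for this result.

The compounds shown leave open how a carboxylic acid, a pyrrolidine amide or a longer ester chain such as butoxy would read on this same carbonyl carbon. Also open, as far as these compounds go, is whether dipropylamino, with its longer chains, would stay within the scatter of diethylamino or move beyond it.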